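Aryl variation next to the acid arm of the shared core

The source may report more compounds than this note shows. Statements on the series, on what has been measured and on what is new or still open speak of the compounds shown alone.

Three compounds share a core that carries a carboxymethyl group and a bis(4-fluorophenyl)methyl group, and differ only in the aryl group on the ring carbon next to the ring nitrogen. In an in vitro assay on HEK385-7 cells for displacement of a labelled ligand from prostaglandin D2 receptor 2 (Homo sapiens) (a higher number here means a weaker inhibitor, a lower number a stronger inhibitor), compound 1 `N#Cc1cc(-c2nc(C(c3ccc(F)cc3)c3ccc(F)cc3)sc2CC(=O)O)ccc1F` gives 57 nM, compound 2 `O=C(O)Cc1sc(C(c2ccc(F)cc2)c2ccc(F)cc2)nc1-c1ccccc1` gives 16 nM and compound 3 `O=C(O)Cc1sc(C(c2ccc(F)cc2)c2ccc(F)cc2)nc1-c1ccoc1` gives 14 nM. Compound 3 has the lowest of the three numbers; its gap to compound 2 is within the scatter, while compound 1 lies a 4.1-fold lower number from compound 1 to compound 3 (0.61 log units; beyond the scatter) and a 3.6-fold lower number from compound 1 to compound 2 (0.55 log units; beyond the scatter) away. The step of a 1.1-fold lower number from compound 2 to compound 3 (0.06 log units; within the scatter) shows that the switch between a six-membered carbon ring and the five-membered oxygen ring is of little consequence here.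

Compound 4 `O=C(O)Cc1sc(C(c2ccc(F)cc2)c2ccc(F)cc2)nc1-c1cccc(F)c1` is the next point: 3-fluorophenyl in place of furan-3-yl on an aromatic carbon. The one ring with a fluorine seen so far, in compound 1, also carries a nitrile, so the two steps from it cannot be separated. A step of at most modest size is expected, a 1.6-fold higher number from compound 3 to compound 4 (0.20 log units; within the scatter), with compound 4 estimated at 22 nM in this assay, ranging from 9 nM to 55 nM.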

Compound 4, half-maximal inhibitory concentration: 1.4 nM
For compound 4 the middle estimate is 16-fold (1.20 log units) above the measured one, outside the stated range (below it).
By their numbers in this assay, from the lowest: compound 4; then compounds 3 and 2 (each within the scatter of the next); then compound 1.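

The aryl group on the aromatic carbon next to the ring nitrogen matters more in this assay than the near match of compound 2 and compound 3 suggested: fluoro in place of hydrogen gives an 11-fold lower number from compound 2 to compound 4 (1.06 log units; beyond the scatter) and 3-fluorophenyl in place of furan-3-yl gives a 10-fold lower number from compound 3 to compound 4 (1.00 log units; beyond the scatter) on the same carbon. 3-Fluorophenyl in place of 3-cyano-4-fluorophenyl gives a 41-fold lower number from compound 1 to compound 4 (1.61 log units; beyond the scatter) and so a ring fluorine alone does not go with a low number, since compound 1 also carries one and goes against that reading. Nothing available accounts for the gain from the added fluorine.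

The compounds shown leave open whether a fluorine elsewhere on the phenyl ring would give the same gain. They also leave open whether a chlorine, a methoxy group or an amine in place of that fluorine would keep the number low.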